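A few compounds are considered here, and "the series" means these few. Any claim that something is new, unique, unknown or untested is made for them only; others in the source may bear on it.

- Compound 1 `COc1ccc2[nH]cc(/C=C(\C#N)C(=O)c3c[nH]c4ccccc34)c2c1`: 21200 nM
- Compound 2 `COc1ccc2[nH]cc(/C=C(\C#N)C(=O)c3c[nH]c4ccc(OC)cc34)c2c1`: 28500 nM
- Compound 3 `N#C/C(=C\c1c[nH]c2ccccc12)C(=O)c1c[nH]c2ccccc12`: 17900 nM

In a functional assay on MIA PaCa-2 cells (Homo sapiens) for cytotoxicity, read by WST assay, with a stated time of 24 h (on this read-out higher numbers stand for weaker inhibition and lower numbers for stronger inhibition), compound 1 gives 21200 nM. Its steps to both other measured compounds stay within the scatter, so it holds no clear rank among them.

Compound 4 `COc1ccc2c(C(=O)/C(C#N)=C/c3c[nH]c4ccc(OC)cc34)c[nH]c2c1` is compound 1 with one change: methoxy in place of hydrogen on an aromatic carbon. This is a methoxy in place of hydrogen on an aromatic carbon.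

Going by the values given here, two measured steps bear on this change. Methoxy in place of hydrogen gave a 1.3-fold higher number from compound 1 to compound 2 (0.13 log units; within the scatter), and hydrogen in place of methoxy gave a 1.2-fold lower number from compound 1 to compound 3 (0.07 log units; within the scatter). Both are small, but neither puts a methoxy at the carbon it occupies in compound 4, so they are only an indirect guide. No step beyond the scatter is therefore expected in this assay, and no direction can be called with confidence.

The estimated change is a 1.1-fold higher number from compound 1 to compound 4 (0.05 log units; within the scatter). The expected value for compound 4 is 24000 nM, with an estimated range from 10000 nM to 55000 nM.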

Compound 4, half-maximal inhibitory concentration: > 50000 nM
Compound 4: a limit, no number (the forecaster's own chance of this, stated with the estimate: 10%); middle value at least 2.0-fold (0.31 log units) away from the limit.
By their numbers in this assay, from the lowest: compounds 3, 1 and 2 (each within the scatter of the next). At a limit, above all of these: compound 4.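

In this assay, methoxy in place of hydrogen on this aromatic carbon gives an at least 2.3-fold higher number from compound 1 to compound 4 (0.37 log units; beyond the scatter), the first step among these compounds to lie beyond the scatter. The same kind of change at a different aromatic carbon gave a 1.3-fold higher number from compound 1 to compound 2 (0.13 log units; within the scatter), which stays within the scatter, so among these compounds the effect of adding a methoxy depends on the carbon that carries it. Compound 4 stands at a limit of the assay, not at a number: the limit of > 50000 nM in this assay, at which 1 of the 4 values shown sits.

Going by these compounds, whether a group other than methoxy on this carbon, such as a fluorine atom, an amine or a carboxylic acid, would give a similar step remains open. On these data alone, it is also open whether this methoxy would give the same step without the methoxy already present in compound 1.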